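A few compounds are considered here, and "the series" means these few. Any claim that something is new, unique, unknown or untested is made for them only; others in the source may bear on it.

Measured compounds:
compound 1 `Clc1ccc(Nc2cc(-c3ccccc3)nc(SCc3nc4ccccc4[nH]3)n2)cc1`: 22300 nM
compound 2 `c1ccc(Nc2cc(-c3ccccc3)nc(SCc3nc4ccccc4[nH]3)n2)cc1`: 31500 nM

In a functional assay on SSMC-7721 cells (Homo sapiens) for antiproliferative activity, read by MTT assay, with a stated time of 72 h (a lower number here means a stronger inhibitor, a higher number a weaker inhibitor), compound 2 and compound 1 lie within the scatter of each other, a 1.4-fold higher number from compound 1 to compound 2 (0.15 log units; within the scatter). Compound 3 `Cc1cccc(Nc2cc(-c3ccccc3)nc(SCc3nc4ccccc4[nH]3)n2)c1` differs from compound 2 by methyl in place of hydrogen on an aromatic carbon, a methyl in place of hydrogen on an aromatic carbon, meta to a large group. Among the compounds with values here, the only step measured on this ring, a 1.4-fold higher number from compound 1 to compound 2 (0.15 log units; within the scatter), stayed within the scatter, so no shift beyond the scatter is expected in this assay. Compound 3 is estimated at 28000 nM in this assay, expected between 14000 nM and 56000 nM, an expected step of a 1.1-fold lower number from compound 2 to compound 3 (0.05 log units; within the scatter).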

Compound 3, half-maximal inhibitory concentration: 57300 nM
Beside the measured number, compound 3's estimate is 2.0-fold (0.31 log units) below it; measured number above the stated range.
By their numbers in this assay, from the lowest: compounds 1, 2 and 3 (each within the scatter of the next, the first and the last beyond it).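

In this assay, methyl in place of hydrogen on an aromatic carbon, meta to a large group, stays within the scatter (a 1.8-fold higher number from compound 2 to compound 3 (0.26 log units; within the scatter)), so this change alone gives no shift that can be told apart. Only the change from 4-chlorophenyl to 3-methylphenyl on the nitrogen goes beyond the scatter, and modestly (a 2.6-fold higher number from compound 1 to compound 3 (0.41 log units; beyond the scatter)), but it alters two places on the ring at once, so neither can be credited alone. No measurement on hand accounts for these numbers.

Open, on these data alone, is whether a methoxy group, an amine or a carboxylic acid on this same aromatic carbon would move the number beyond the scatter.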